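The compounds below may be only part of what the source reports. "The series", "measured", "known", "first", "only" and "open" are said of these compounds alone.

Working notes on the series. Compound 1 `Fc1ccc(-c2ccc3c(NCCCNCc4ccco4)ccnc3c2)cc1` gives 9.47 in a physicochemical assay for acid dissociation, and stands level with compound 2 `FC(F)(F)c1cc(-c2ccc3c(NCCCNCc4ccco4)ccnc3c2)cc(C(F)(F)F)c1`, which gives 9.47, and with compound 3 `COc1ccc(F)cc1CNCCCNc1ccnc2cc(-c3ccc(F)cc3)ccc12`, which gives 9.47. Going by the values given here, the one step recorded, no change at the digits printed from compound 1 to compound 3 (within the scatter), replaces furan-2-yl with 5-fluoro-2-methoxyphenyl on the saturated chain carbon bound to the amine nitrogen. Compounds 1 and 2 differ in the aryl group on the shared core and show the same value.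

Compound 4 `COc1ccc(-c2ccc3c(NCCCNCc4ccco4)ccnc3c2)cc1` is not yet measured. It differs from compound 1 by methoxy in place of fluoro on an aromatic carbon. Among the compounds with values here, no recorded step varies this position directly, but the change lies far from the amine, and the values of compound 1 and compound 2 show no shift from a change in the same ring. The expected step of no change at the digits printed from compound 1 to compound 4 (within the scatter) is therefore none beyond the scatter. Compound 4 is estimated at 9.47, between 9.2 and 9.75.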

Compound 4, acid dissociation constant: 9.47
Compound 4: the middle estimate sits on the measured number at the digits printed; the measured number falls inside the stated range.
By their numbers in this assay, from the lowest: compounds 1, 2, 3 and 4 (each within the scatter of the next).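

In this assay, 4-fluorophenyl to 4-methoxyphenyl gives no change at the digits printed from compound 1 to compound 4 (within the scatter), the first single-place step read at this aromatic carbon, para to a large group. Compound 2 had shown the same value with a different aryl group, but not this direct exchange of fluoro for methoxy. No measurement on hand offers an explanation for this result. Going by these compounds, whether an amine or a carboxylic acid in place of methoxy on this ring would leave the value level remains open. The same holds for a longer chain on the amine nitrogen.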